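The source may hold more compounds than are shown below. What is called first, only, known or untested is meant among the compounds shown, and "the series" means these compounds.

Three close relatives share one core, and differ only in the group carried on an amine nitrogen. Compound 1 `Cc1ccc(S(=O)(=O)/N=C(/CCNC2=CC(=O)c3ccccc3C2=O)Nc2ccc(Cl)cc2)cc1` carries a 4-chlorophenyl group there, and in a functional assay on HeLa cells (Homo sapiens) for cytotoxicity, read by MTT assay, with a stated time of 48 h (a higher number here means a weaker inhibitor, a lower number a stronger inhibitor), compound 1 gives 13400 nM. Compound 2 `COc1ccc(N/C(CCNC2=CC(=O)c3ccccc3C2=O)=N\S(=O)(=O)c2ccc(C)cc2)c(OC)c1` carries a 2,4-dimethoxyphenyl group instead, and in this assay compound 2 gives 67600 nM. Compound 3 `Cc1ccc(S(=O)(=O)/N=C(/CCNC2=CC(=O)c3ccccc3C2=O)NC(C)C)cc1` carries an isopropyl group, and in this assay compound 3 gives 30200 nM, which places it second highest of the three numbers. The swaps between them were all modest: a 5.0-fold higher number from compound 1 to compound 2 (0.70 log units; beyond the scatter), a 2.3-fold higher number from compound 1 to compound 3 (0.35 log units; beyond the scatter) and a 2.2-fold lower number from compound 2 to compound 3 (0.35 log units; beyond the scatter).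

Compound 4 `Cc1ccc(S(=O)(=O)/N=C(/CCNC2=CC(=O)c3ccccc3C2=O)NCc2ccccc2)cc1` is the next step from compound 3: benzyl in place of isopropyl on an amine nitrogen. Among the measured steps, those from compound 1 and compound 2 to compound 3 bear on it, since each exchanges a ring-bearing group for isopropyl at the same nitrogen, and both stayed within a narrow band. Putting a ring back, here with one carbon between it and the nitrogen, is therefore expected to move this assay only modestly, if at all, most plausibly toward a somewhat lower number, as a 1.5-fold lower number from compound 3 to compound 4 (0.18 log units; within the scatter). The estimate for compound 4 in this assay is 20000 nM, with a range from 8000 nM to 60000 nM.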

Compound 4, half-maximal inhibitory concentration: 3980 nM
For compound 4 the middle estimate is 5.0-fold (0.70 log units) above the measured one; the measured number lies below the stated range.
By their numbers in this assay, from the lowest: compound 4; then compound 1; then compound 3; then compound 2.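

In this assay, for the compounds shown here, this nitrogen tolerates a wider spread than the first three compounds suggested, with a 7.6-fold lower number from compound 3 to compound 4 (0.88 log units; beyond the scatter) and a 3.4-fold lower number from compound 1 to compound 4 (0.53 log units; beyond the scatter) and, the only large step at this position, a 17-fold lower number from compound 2 to compound 4 (1.23 log units; beyond the scatter) and so benzyl gives a number clearly lower than each of the other three groups. A ring alone does not set the order: compound 1, compound 2 and compound 4 all carry one, yet compound 2 has a higher number than compound 3, which has no ring, while compound 4 has a lower number than compound 3. No measurement offered here gives a reason for the gain seen with benzyl.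

Still open, on these data alone, is whether this gain is particular to benzyl or extends to a longer chain ending in a ring, such as 2-phenylethyl, or to a small change on the benzyl ring itself, such as 4-chlorobenzyl or 2,4-dimethoxybenzyl. Those last two would also show whether the substituents that separate compound 1 from compound 2 keep the same order when they sit on a benzyl group.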